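Acetyl for isopropyl on a ring amine nitrogen

The source may report more compounds than this note shows. Statements on the series, on what has been measured and on what is new or still open speak of the compounds shown alone.

Compound 1 `C=CC(=O)Nc1cccc(-n2c(-c3nc(-c4cnn(C)c4)cnc3N)nc3ccccc32)c1` gives 24 mL.min-1.g-1 in an ADME assay on liver for metabolic stability, with Liver microsome (Homo sapiens) as the target, using microsomes; a higher number here means faster removal of the compound, a lower number slower removal.
Compound 2 `C=CC(=O)Nc1cccc(-n2c(-c3nc(-c4cnn(CCN5CCN(C)CC5)c4)cnc3N)nc3ccccc32)c1` gives 60 mL.min-1.g-1 in this assay.
Compound 3 `C=CC(=O)Nc1cccc(-n2c(-c3nc(-c4cnn(C5CCN(C(C)C)CC5)c4)cnc3N)nc3ccccc32)c1` gives 37 mL.min-1.g-1 in this assay.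

Compound 3 stands second highest of the three numbers. The step of a 1.5-fold higher number from compound 1 to compound 3 (0.19 log units; within the scatter) lies within the scatter, as does the step of a 1.6-fold lower number from compound 2 to compound 3 (0.21 log units; within the scatter), so compound 3 cannot be ordered against either of them. Among the measured compounds shown here, only the step of a 2.5-fold higher number from compound 1 to compound 2 (0.40 log units; beyond the scatter) reaches beyond the scatter, and it is modest.

Compound 4 `C=CC(=O)Nc1cccc(-n2c(-c3nc(-c4cnn(C5CCN(C(C)=O)CC5)c4)cnc3N)nc3ccccc32)c1` differs from compound 3 in one place: acetyl in place of isopropyl on an amine nitrogen in a ring. None of the three measured steps touches this amine nitrogen; all of them exchange the whole group on the aromatic nitrogen, and two of the three stayed within the scatter. For the measured compounds named here, there is thus no direct precedent, and the nearest comparisons suggest little movement. The step of a 1.2-fold lower number from compound 3 to compound 4 (0.09 log units; within the scatter) is expected to stay within the scatter. Compound 4 is therefore estimated to give 30 mL.min-1.g-1 in this assay, with a range from 14 mL.min-1.g-1 to 65 mL.min-1.g-1.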

Compound 4, intrinsic clearance in microsomes in the Liver microsome assay: > 300 mL.min-1.g-1
Compound 4 ended at the assay's limit (the forecaster's own chance of this, stated with the estimate: 5%); middle value at least 10-fold (1.00 log units) from the limit.
By their numbers in the Liver microsome assay, from the lowest: compounds 1, 3 and 2 (each within the scatter of the next, the first and the last beyond it). At a limit, above all of these: compound 4.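

Among the compounds shown here, in the Liver microsome assay compound 4 sits at a limit of the assay, not at a number: the limit of > 300 mL.min-1.g-1 in the Liver microsome assay, at which 1 of the 4 values shown sits. The group on the amine nitrogen in the ring proves to matter, which the earlier compounds could not show, since they differ only in the whole group on the aromatic nitrogen: in the Liver microsome assay, acetyl in place of isopropyl gives an at least 8.1-fold higher number from compound 3 to compound 4 (0.90 log units; beyond the scatter). In the Liver microsome assay the exchanges of that whole group also now reach beyond the scatter, with an at least 5.0-fold higher number from compound 2 to compound 4 (0.69 log units; beyond the scatter) and an at least 12-fold higher number from compound 1 to compound 4 (1.09 log units; beyond the scatter).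

In a physicochemical assay for solubility, at pH 7.4 (a higher number here means a more soluble compound, a lower number a less soluble compound), compound 3 gives < 10000 nM, which is a limit of the assay. In the physicochemical assay compound 4 gives < 10000 nM, which is also a limit of the assay. From the compounds shown here alone, in the physicochemical assay compound 3 and compound 4 both sit at a limit, so the step between them cannot be read: the limit of < 10000 nM in the physicochemical assay, at which 2 of the 2 values shown sit. It remains open how a methyl or a methylsulfonyl on the same amine nitrogen would fall in the Liver microsome assay, whether near compound 3 or near compound 4.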